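A few compounds are considered here, and "the series" means these few. Any claim that something is new, unique, unknown or untested is made for them only; others in the source may bear on it.

Working notes on the series. Going by the values given here, in a functional assay on cells for antagonist activity at Free fatty acid receptor 1 (Homo sapiens), read by TR-FRET and inositol phosphate accumulation, with a stated time of 2 h (on this read-out higher numbers stand for weaker inhibition and lower numbers for stronger inhibition), compound 1 `Cc1cc(COc2ccccc2)nc(-c2ccccn2)n1` gives 794 nM, the second highest of the three numbers measured so far. Compound 2 `Cc1cc(COc2cccc(Cl)c2)nc(-c2ccccn2)n1` gives 398 nM, and a 2.0-fold lower number from compound 1 to compound 2 (0.30 log units; within the scatter). Compound 3 `COc1ccccc1OCc1cc(C)nc(-c2ccccn2)n1` gives 2000 nM, and a 2.5-fold higher number from compound 1 to compound 3 (0.40 log units; beyond the scatter). The unmeasured compound 4 `COc1ccc(OCc2cc(C)nc(-c3ccccn3)n2)cc1` differs from compound 1 by methoxy in place of hydrogen on an aromatic carbon. Among the compounds with values here, of the two measured steps, only the one from compound 1 to compound 3 bears on this change, as it also brings a methoxy group onto the six-membered aromatic ring of carbon only, though at a different place; that step was modest and in the direction of weaker inhibition. The chloro step is within the scatter and concerns another group, so it gives no direction here. A small step toward weaker inhibition in this assay is therefore expected, possibly no larger than the scatter. Compound 4 is estimated at 1200 nM, with a range from 500 nM to 3000 nM. The expected step is a 1.5-fold higher number from compound 1 to compound 4 (0.18 log units; within the scatter).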

Compound 4, half-maximal inhibitory concentration: 7940 nM
Compound 4: middle estimate off by 6.6-fold (0.82 log units), on the low side; the measured number lies above the stated range.
By their numbers in this assay, from the lowest: compounds 2 and 1 (each within the scatter of the next); then compound 3; then compound 4.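

In this assay, methoxy para to a large group gives a 10-fold higher number from compound 1 to compound 4 (1.00 log units; beyond the scatter), a larger step than a 2.5-fold higher number from compound 1 to compound 3 (0.40 log units; beyond the scatter), where the methoxy group stands elsewhere on the same six-membered aromatic ring. The same replacement therefore does not carry one fixed size on this ring: its step depends on where the group stands, and the direction toward weaker inhibition is shared by both methoxy compounds. The data on hand give no measured basis for explaining the larger step at this place.

Open, on these data alone, is whether the step at this place belongs to methoxy alone, or whether a hydroxyl group, a fluorine atom or a longer ethoxy group there would give a step of similar size. Also open, as far as these compounds go, is how the chloro group of compound 2 would fare at this place.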